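This account rests on a few compounds, and the source may have more. Where it says the series, first, only, none or still open, it means among the compounds named here.

Three compounds have numbers in an ADME assay (Rattus norvegicus, strain Sprague Dawley) for metabolic stability; on this read-out lower numbers stand for a shorter-lived compound and higher numbers for a longer-lived compound. Compound 1 `Cc1ccnc(NCc2ccc(-c3ccccc3C(=O)O)cc2)c1NC(=O)CC#N` gives 2 h. Compound 2 `COC(=O)c1ccccc1-c1ccc([C@@H](C)Nc2nccc(C)c2NC(=O)CC#N)cc1` gives 0.2 h. Compound 3 `CNC(=O)c1ccccc1-c1ccc(CNc2ncccc2NC(=O)CC(F)(F)F)cc1` gives 0.3 h. Compound 2 stands lowest of the three: compound 3 lies within the usual scatter of it, while compound 1 lies higher, beyond the scatter. Compound 4 `COC(=O)c1ccccc1-c1ccc([C@@H](C)Nc2nccc(C)c2NC(=O)CC(F)(F)F)cc1` has not been measured; it differs from compound 2 by trifluoromethyl in place of cyano on a saturated chain carbon bound to a carbonyl carbon. Among the measured compounds shown here, no pair of measured compounds differs in one place only. Though compound 3 differs from compound 2 in more than one place, it carries the same trifluoromethyl group, and compound 3 gives 0.3 h, within the scatter of the value of compound 2, 0.2 h. The step of a 1.3-fold higher number from compound 2 to compound 4 (0.10 log units; within the scatter) is therefore expected to stay within the scatter, in no clear direction. Compound 4 is expected at 0.25 h, between 0.1 h and 0.6 h.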

Compound 4, half-life: 0.9 h
The estimate for compound 4 lay 3.6-fold (0.56 log units) below the measured number; the measured number lies above the stated range.
By their numbers in this assay, from the lowest: compounds 2 and 3 (each within the scatter of the next); then compound 4; then compound 1.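

In this assay, among the compounds shown here, trifluoromethyl in place of cyano on a saturated chain carbon bound to a carbonyl carbon gives a 4.5-fold higher number from compound 2 to compound 4 (0.65 log units; beyond the scatter), the first step that can be read at a single place. This place therefore matters to the read-out, at least on the core of compound 2. Nothing at hand accounts for the step. Going by these compounds, whether the same change carries over to the cores of compound 1 and compound 3 remains open. So does the outcome with an amine or a longer chain at this place.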